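Naphthalen-1-yl in place of 4-(tert-butyl)phenyl on Vero cells

The compounds below may be only part of what the source reports. "The series", "measured", "known", "first", "only" and "open" are said of these compounds alone.

Of the compounds shown here, three have been measured in an ADME assay on Vero cells (Chlorocebus sabaeus) for cytotoxicity, read by MTT assay, tested at 50 uM; a higher number here means a weaker effect of the compound at the concentration tested, a lower number a stronger effect. Compound 1 `CSc1ccc(C(=O)/C(=C/c2ccccn2)c2ccc(Cl)c(Cl)c2)cc1` gives 93.6%. Compound 2 `CCOC(=O)C(C(=O)c1ccc(OC)cc1)C(NC(C)=O)c1ccc(C(C)C)cc1` gives 96.5%. Compound 3 `CCOC(=O)C(C(=O)c1ccc(OC)cc1)C(NC(C)=O)c1ccc(C(C)(C)C)cc1` gives 92.3%. For the measured compounds named here, the one single-point step among them, a number 4.2 percentage points lower from compound 2 to compound 3 (within the scatter), changes methyl in place of hydrogen on a saturated chain carbon bound to an aromatic carbon and two saturated chain carbons. On these numbers compound 3 sits in one band with compound 1 and compound 2; none of the gaps between the three exceeds the scatter, so no order can be read from them.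

Compound 4 `CCOC(=O)C(C(=O)c1ccc(OC)cc1)C(NC(C)=O)c1cccc2ccccc12` has not been measured. It differs from compound 3 by naphthalen-1-yl in place of 4-(tert-butyl)phenyl on a saturated chain carbon bound to an amide-type nitrogen and a saturated chain carbon. Going by the values given here, the only measured step touches the same part of the molecule, the group on the saturated chain carbon bound to the amide-type nitrogen, and it stayed within the scatter. Among the compounds with values here, no measured step replaces one aromatic ring with two, so that part of the change is untested. The step of a number 0.3 percentage points lower from compound 3 to compound 4 (within the scatter) is therefore expected to stay inside the scatter. Compound 4 is expected to give 92%, with a range from 80% to 100%, because a number 4.2 percentage points lower from compound 2 to compound 3 (within the scatter) stayed within the scatter.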

Compound 4, a percentage reported as activity, at one concentration (the size of the read-out at that concentration, not a potency): 98.7%
For compound 4 the middle estimate is 6.7 percentage points below the measured one; the range from low to high includes it.
By their numbers in this assay, from the lowest: compounds 3, 1, 2 and 4 (each within the scatter of the next).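

For the compounds shown here, at the saturated chain carbon bound to an amide-type nitrogen and a saturated chain carbon, the earlier compounds had only varied a small alkyl group on a single aromatic ring. Going by these compounds alone, compound 4 is the first to carry two six-membered aromatic rings there, and in this assay the result is a number 6.4 percentage points higher from compound 3 to compound 4 (within the scatter) and a number 2.2 percentage points higher from compound 2 to compound 4 (within the scatter), so this larger change to the ring system shows no effect that can be told from the scatter at this position. Nothing available here gives a reason for this result.

All three groups shown at this position contain carbon and hydrogen only. As far as these compounds go, what a carboxylic acid or an amine on the aromatic ring would do there remains open, as does whether the shared core would tolerate losing the aromatic ring altogether in favour of a longer chain.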